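This account rests on a few compounds, and the source may have more. Where it says the series, first, only, none or still open, it means among the compounds named here.

Compound 1, `COc1ccc(S(=O)(=O)Nc2cccc3cc[nH]c23)cc1`: in a functional assay on KB cells (Homo sapiens) for antiproliferative activity, read by colorimetric assay and MTT assay (on this read-out higher numbers stand for weaker inhibition and lower numbers for stronger inhibition), compound 1 gives 0.67 ug/mL.
Compound 2, `COc1ccc(S(=O)(=O)Nc2ccc(Cl)c3cc[nH]c23)cc1`: in this assay compound 2 gives 0.92 ug/mL.

For the measured compounds named here, compound 2 stands alongside compound 1 on these two numbers: the one step that separates them, a 1.4-fold higher number from compound 1 to compound 2 (0.14 log units; within the scatter), lies within the scatter, so the two values cannot be told apart by this assay.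

Compound 3 is `N#Cc1ccc(S(=O)(=O)Nc2ccc(Cl)c3cc[nH]c23)cc1`. It differs from compound 2 in a single place: cyano in place of methoxy on an aromatic carbon. The group that leaves and the group that enters are of the same size in heavy atoms, and each carries one hydrogen-bond acceptor and no donor; the entering group brings a triple bond outside aromatic rings. Going by the values given here, no measured step bears directly on such a swap. Among the compounds with values here, the only measured step, from compound 1 to compound 2, concerns a chloro in place of hydrogen on the other ring and was itself within the scatter. With nothing to suggest a move in either direction, the step of a 1.0-fold lower number from compound 2 to compound 3 (0.01 log units; within the scatter) is expected to stay within the scatter. Compound 3 is therefore estimated at 0.9 ug/mL, with a range from 0.4 ug/mL to 2 ug/mL.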

Compound 3, half-maximal inhibitory concentration: 15 ug/mL
Compound 3: the middle estimate sits 17-fold (1.22 log units) below what was measured; measured number above the stated range.
By their numbers in this assay, from the lowest: compounds 1 and 2 (each within the scatter of the next); then compound 3.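

The position on the ring that bears the methoxy in compound 2, para to a large group, proves sensitive in this assay, where cyano in place of methoxy gives a 16-fold higher number from compound 2 to compound 3 (1.21 log units; beyond the scatter), a clear loss of inhibition. The earlier step, a 1.4-fold higher number from compound 1 to compound 2 (0.14 log units; within the scatter), lay within the scatter and gave no sign that a single swap on this series could have so large an effect, least of all one between two groups that match in heavy atoms, hydrogen-bond donors and hydrogen-bond acceptors. Nothing available here shows what lies behind this loss.

The compounds shown hold only methoxy and cyano at this position, so it remains open whether the loss reflects the departure of the methoxy or the arrival of the cyano, and how a methyl, an amine or a carboxylic acid would behave there. Also open, from the compounds shown here alone, is whether the same swap would produce a step of similar size on the core of compound 1, which has hydrogen where compound 2 has chloro.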